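The source may hold more compounds than are shown below. What is called first, only, known or untested is meant among the compounds shown, and "the series" means these compounds.

Measured in a functional assay on MCF7 cells (Homo sapiens) for cytotoxicity, read by MTT assay, with a stated time of 72 h; a lower number here means a stronger inhibitor, a higher number a weaker inhibitor:
- compound 1 `CC[S+]([O-])CCCCN=C=S` gives 8260 nM
- compound 2 `CCCC[S+]([O-])CCCCN=C=S` gives 5840 nM
- compound 3 `CC(C)C[S+]([O-])CCCCN=C=S` gives 3660 nM

Compound 3, at 3660 nM, is clearly separated from only one of the other two compounds. The data show a 2.3-fold lower number from compound 1 to compound 3 (0.35 log units; beyond the scatter), but also a 1.6-fold lower number from compound 2 to compound 3 (0.20 log units; within the scatter).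

The next structure is compound 4 `[O-][S+](CCCCN=C=S)Cc1ccco1`, which carries furan-2-yl in place of isopropyl on a saturated chain carbon bound to a sulfur.

For the measured compounds named here, no measured step brings in a ring, so the series offers no direct precedent for this change. The nearest evidence is the set of changes to the group on the same sulfur. These gave a 1.4-fold lower number from compound 1 to compound 2 (0.15 log units; within the scatter) and a 1.6-fold lower number from compound 2 to compound 3 (0.20 log units; within the scatter), while the largest, a 2.3-fold lower number from compound 1 to compound 3 (0.35 log units; beyond the scatter), was only modest. With steps of that size among compound 1, compound 2 and compound 3, no step beyond the scatter is expected in this assay, and the direction cannot be called with any confidence.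

The estimate amounts to a 1.1-fold higher number from compound 3 to compound 4 (0.04 log units; within the scatter), an expected change within the scatter. Compound 4 is estimated at 4000 nM, with an expected range from 1800 nM to 8500 nM.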

Compound 4, half-maximal inhibitory concentration: 5680 nM
Compound 4: the middle estimate sits 1.4-fold (0.15 log units) below what was measured; the range from low to high includes it.
By their numbers in this assay, from the lowest: compounds 3, 4, 2 and 1 (each within the scatter of the next, the first and the last beyond it).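

In this assay, the first ring at this position, furan-2-yl on a saturated chain carbon bound to a sulfur, gives a step from each open-chain group that stays inside the usual variation: isopropyl (a 1.6-fold higher number from compound 3 to compound 4 (0.19 log units; within the scatter)), propyl (a 1.0-fold lower number from compound 2 to compound 4 (0.01 log units; within the scatter)) and methyl (a 1.5-fold lower number from compound 1 to compound 4 (0.16 log units; within the scatter)). The earlier compounds shown here held only open chains here, and this result shows that a five-membered aromatic ring with one hetero atom and one hydrogen-bond acceptor can take the place of such a chain with no step beyond the scatter, even though compound 1 and compound 3 are separated by more than the scatter and compound 4 lies within the scatter of both, so it cannot be ranked with either. No independent measurement is available that would account for this result.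

The compounds shown leave open whether a phenyl ring, or a thiophene ring with sulfur in place of the furan oxygen, would fall in the same range at this position. They also leave open how an amine, a carboxylic acid or a longer chain carrying the furan-2-yl ring would read in this assay.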